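Replacing cyclopropyl with a carbamoylphenyl group on the shared core

The compounds below may be only part of what the source reports. "The series", "measured", "known", "first", "only" and "open" are said of these compounds alone.

The study concerns two measured analogues and one untested compound sharing one core. Compound 1 `CNc1nc(NCCCN(C)C)c2sc(-c3ccc(C(F)(F)F)cc3)cc2n1` carries a 3-(dimethylamino)propyl group on a nitrogen on an aromatic ring; in a physicochemical assay for solubility, in phosphate buffer, at pH 6.5 (on this read-out lower numbers stand for lower solubility and higher numbers for higher solubility), compound 1 gives 177 ug/mL. Compound 2 `CNc1nc(NC2CC2)c2sc(-c3ccc(C(F)(F)F)cc3)cc2n1` carries cyclopropyl in that place. In this assay compound 2 reaches only a limit, < 5 ug/mL, as noted in the limit of < 5 ug/mL in this assay, at which 1 of the 2 values shown sits. The step of an at least 35-fold lower number from compound 1 to compound 2 (1.54 log units; beyond the scatter) is therefore large and downward, and compound 2 stands at the bottom of the two numbers shown.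

Compound 3 `CNc1nc(Nc2cccc(C(N)=O)c2)c2sc(-c3ccc(C(F)(F)F)cc3)cc2n1` is not yet measured. It differs from compound 2 by 3-carbamoylphenyl in place of cyclopropyl on a nitrogen on an aromatic ring. No measured step covers this exact exchange; the only step shown, an at least 35-fold lower number from compound 1 to compound 2 (1.54 log units; beyond the scatter), concerns the removal of the 3-(dimethylamino)propyl group. Since compound 2 sits at a limit, any increase from compound 2 to compound 3 beyond the scatter would be detectable, while a decrease would not. The expected step is an at least 1.6-fold higher number from compound 2 to compound 3 (0.20 log units; that floor lies within the scatter), a modest rise. For compound 3 the estimate in this assay is 8 ug/mL, with a range from 2 ug/mL to 30 ug/mL.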

Compound 3, solubility: 8 ug/mL
Estimate against measurement, compound 3: no gap at the digits printed, within the range that was stated.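

Compound 2 stands at a limit in this series, not at a number: the limit of < 5 ug/mL in this assay, at which 1 of the 3 values shown sits.

In this assay, as far as these compounds go, the exchange of cyclopropyl for 3-carbamoylphenyl on a nitrogen on an aromatic ring gives an at least 1.6-fold higher number from compound 2 to compound 3 (0.20 log units; that floor lies within the scatter); this is a floor only, and the true size of the change at this position stays unknown. Against the 3-(dimethylamino)propyl group, 3-carbamoylphenyl gives a 22-fold lower number from compound 1 to compound 3 (1.34 log units; beyond the scatter), so this larger aromatic group, with its hydrogen-bond donor and acceptor, does not bring the number back to the level seen with the 3-(dimethylamino)propyl chain.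

The compounds shown leave open whether a carboxylic acid or a shorter chain ending in a dimethylamino group at this place would come near compound 1 at 177 ug/mL in this assay or stay near compound 3. They also leave open how a plain phenyl group, without the carbamoyl group, would compare with 3-carbamoylphenyl, and with it whether the ring or the carbamoyl group accounts for the number of compound 3.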